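This account rests on a few compounds, and the source may have more. Where it says the series, first, only, none or still open, it means among the compounds named here.

Compound 3 `Cc1c(Cc2ccc(OC(F)(F)F)cc2)c(=O)oc2cc(OCC(O)CN3CCC(C(N)=O)CC3)ccc12` gives 68200 nM in an ADME assay on A549 cells (Homo sapiens) for cytotoxicity, read by CellTiter-Glo; on this read-out lower numbers stand for higher toxicity in this test and higher numbers for lower toxicity in this test. Compound 1 `Cc1c(Cc2cccc(F)c2)c(=O)oc2cc(OCC(O)CN3CCC(C(N)=O)CC3)ccc12` gives 53300 nM in this assay, and compound 2 `Cc1c(Cc2ccc(F)cc2Cl)c(=O)oc2cc(OCC(O)CN3CCC(C(N)=O)CC3)ccc12` gives 90800 nM. On these numbers compound 3 lies between the other two, the steps being a 1.3-fold higher number from compound 1 to compound 3 (0.11 log units; within the scatter) and a 1.3-fold lower number from compound 2 to compound 3 (0.12 log units; within the scatter), both within the scatter, as is a 1.7-fold higher number from compound 1 to compound 2 (0.23 log units; within the scatter). Compound 4 `Cc1c(Cc2ccc(-c3ccc(Cl)cc3)cc2)c(=O)oc2cc(OCC(O)CN3CCC(C(N)=O)CC3)ccc12` differs from compound 3 by 4-chlorophenyl in place of trifluoromethoxy on an aromatic carbon. The three measured steps each exchange one substituted phenyl for another on the same saturated chain carbon; none adds a second aromatic ring, so they bear on this change only loosely, and all are within the scatter. No step beyond the scatter is therefore expected for compound 4, a 1.2-fold lower number from compound 3 to compound 4 (0.09 log units; within the scatter), in either direction. Compound 4 is estimated at 55000 nM, within 20000 nM to 130000 nM.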

Compound 4, half-maximal cytotoxic concentration: 32900 nM
For compound 4 the middle estimate is 1.7-fold (0.22 log units) above the measured one; low and high end bracket the measured number.
By their numbers in this assay, from the lowest: compounds 4, 1, 3 and 2 (each within the scatter of the next, the first and the last beyond it).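

For the compounds shown here, putting 4-chlorophenyl in place of trifluoromethoxy on this aromatic carbon, para to a large group, gives the first single change beyond the scatter in this assay, a 2.1-fold lower number from compound 3 to compound 4 (0.32 log units; beyond the scatter), a modest step. Going by these compounds alone, the earlier exchanges of one substituted phenyl for another all stayed within the scatter, so a second aromatic ring here is the first change that moves the number. Nothing measured on these compounds accounts for the step.

Still open, as far as these compounds go, is whether the ring or its chlorine carries the step. A plain phenyl, a pyridine or a morpholine on this carbon would separate the two.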